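Lengthening the Hydroxamate Chain by One Carbon

The source may report more compounds than this note shows. Statements on the series, on what has been measured and on what is new or still open speak of the compounds shown alone.

Compound 1 `Nc1nc2cc(-c3nn(CCCCCCCCCC(=O)NO)c4ncnc(N)c34)ccc2o1` gives 98.2% in an assay on isolated protein for inhibition of protein deacetylase HDAC6 (Homo sapiens), with a stated time of 15 min, tested at 1 uM; on this read-out lower numbers stand for less inhibition and higher numbers for more inhibition at the one concentration tested (going by the name of the read-out).
Compound 2 `Nc1ncnc2c1c(-c1cnc3[nH]ccc3c1)nn2CCCCCCCCCC(=O)NO` gives 98.3% in this assay.
Compound 3 `Nc1nc2cc(-c3nn(CCCCCC(=O)NO)c4ncnc(N)c34)ccc2o1` gives 97.8% in this assay.

All three numbers sit close to the top of the scale. The step of a number 0.4 percentage points lower from compound 1 to compound 3 (within the scatter) lies within the scatter. The gap between compound 3 and compound 2 also lies within the scatter, so compound 3 stands level with the other two. Compound 4 `Nc1nc2cc(-c3nn(CCCCCCC(=O)NO)c4ncnc(N)c34)ccc2o1` has not yet been measured. It differs from compound 3 by (hydroxycarbamoyl)methyl in place of hydroxycarbamoyl on a saturated chain carbon, five bonds along the chain from an aromatic nitrogen.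

The step that bears most directly on this change is a number 0.4 percentage points lower from compound 1 to compound 3 (within the scatter), in which the same kind of chain shortening by several carbons left the read-out essentially unchanged. The step of a number 0.1 percentage points higher from compound 1 to compound 2 (within the scatter), a swap of the aromatic group rather than the chain, also left the number where it was. Since a far larger chain change moved nothing beyond the scatter, a single added carbon is expected to move nothing either, so compound 4 is expected to show no change at the digits printed from compound 3 to compound 4 (within the scatter). Compound 4 is therefore estimated at 97.8%, within 92% to 99.8%.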

Compound 4, a percentage reported as inhibition, at one concentration (the size of the read-out at that concentration, not a potency): 99%
Compound 4: middle estimate off by 1.2 percentage points, on the low side; the range from low to high includes it.
By their numbers in this assay, from the lowest: compounds 3, 1, 2 and 4 (each within the scatter of the next).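

Compound 4 gives the one-carbon change its own direct reading at this chain position in this assay: a number 1.2 percentage points higher from compound 3 to compound 4 (within the scatter). Compared with the longer chain, the reading is a number 0.8 percentage points higher from compound 1 to compound 4 (within the scatter), so the three chain lengths in compound 3, compound 4 and compound 1 stand level, all close to the top of the scale. Nothing measured here offers a reason for this flat picture.

With all three numbers so close to the top of the scale at a single concentration, any real differences between these chain lengths would stay hidden. From the compounds shown here alone, it also remains open whether the number would hold with a carboxylic acid in place of the hydroxycarbamoyl group at the chain end, or with a chain shorter than that of compound 3.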